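Swapping 2-ethoxyphenyl for 2-fluoro-3-methylphenyl on a shared core

The source may hold more compounds than are shown below. What is called first, only, known or untested is meant among the compounds shown, and "the series" means these compounds.

In an ADME assay on cells (Hepatocyte, Rattus norvegicus, strain Han Wistar) for metabolic stability, read by LC-MS, with a stated time of 90 min, tested at 1 uM, in the presence of a further agent that is not named here (on this read-out higher numbers stand for fast clearance and lower numbers for slow clearance), compound 1 (`CC[C@@H](Nc1c(C#N)c(-c2ccc(-c3cccc(Cl)c3F)cc2)nc2cnccc12)C(N)=O`) gives 5 mL/min/kg and compound 2 (`CCOc1ccccc1-c1ccc(-c2nc3cnccc3c(N[C@H](CC)C(=O)O)c2C#N)cc1`) gives 8.33 mL/min/kg as its number, so the two stand within the usual scatter of repeated measurements of each other. Compound 2 therefore cannot be told apart from compound 1 on these numbers.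

Compound 3 (`CC[C@@H](Nc1c(C#N)c(-c2ccc(-c3cccc(C)c3F)cc2)nc2cnccc12)C(=O)O`) has not been measured yet. Within the data shown here, its one change from compound 2 is 2-fluoro-3-methylphenyl in place of 2-ethoxyphenyl, on an aromatic carbon of a six-membered aromatic ring of carbon only, para to a large group (2-fluoro-3-methylphenyl in place of 2-ethoxyphenyl on an aromatic carbon).

Among the measured compounds shown here, no two measured compounds differ in one place only, so no measured step shows what such a swap does. For the measured compounds named here, the only guide is that compound 1 at 5 mL/min/kg and compound 2 at 8.33 mL/min/kg lie within the scatter even though they differ in more than one place. The estimated step of a 1.2-fold lower number from compound 2 to compound 3 (0.08 log units; within the scatter) is thus expected to stay within the scatter, with no firm direction. Compound 3 is expected to read 7 mL/min/kg in this assay (estimated range 3.5 mL/min/kg to 15 mL/min/kg).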

Compound 3, clearance: 38.3 mL/min/kg
Estimate against measurement, compound 3: 5.5-fold (0.74 log units) below; measured number above the stated range.
By their numbers in this assay, from the lowest: compounds 1 and 2 (each within the scatter of the next); then compound 3.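

At this place, on an aromatic carbon of a six-membered aromatic ring of carbon only, para to a large group, the choice of ring clearly matters: in this assay, putting 2-fluoro-3-methylphenyl in place of 2-ethoxyphenyl gives a 4.6-fold higher number from compound 2 to compound 3 (0.66 log units; beyond the scatter). Among these compounds, this is the first comparison here between two compounds that differ in one place only, and it shows that a change at this outer ring alone, with the rest of the molecule held fixed, can move clearance beyond the usual scatter, with 2-ethoxyphenyl the more slowly cleared of the two. Nothing measured here accounts for the size or direction of this step, so the result stands as an observation without an explanation.

From the compounds shown here alone, the swap removes the ethoxy group and adds both a fluorine and a methyl group at once, so it remains open which of these changes carries the step; a plain phenyl, 2-methoxyphenyl or 2-fluorophenyl ring on the shared core would help separate them. Going by these compounds, it also remains open whether the step would hold with a primary amide in place of the carboxylic acid.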